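The compounds below may be only part of what the source reports. "The series", "measured", "known", "first", "only" and "open" are said of these compounds alone.

Measured compounds:
- compound 1 `COc1cc2c(cc1OC)CN(CCCCCCC(Sc1ccccc1)c1ccccc1)CC2` — in a functional assay on S1B1-20 cells (Homo sapiens) (on this read-out higher numbers stand for weaker inhibition and lower numbers for stronger inhibition), compound 1 gives 3820 nM
- compound 2 `COC(=O)C(CCCN1CCc2cc(OC)c(OC)cc2C1)(Sc1ccc(C)cc1)c1ccc(OC)c(OC)c1` — compound 2 gives 1470 nM
- compound 3 `COc1ccc(C(CCCCCN2CCc3cc(OC)c(OC)cc3C2)Sc2ccc(C)cc2)cc1OC` — compound 3 gives 330 nM

Compound 3 stands lowest of the three numbers measured in this assay. Its nearest neighbour is compound 2, whose number is higher by a gap beyond the scatter; compound 1 lies furthest, also beyond the scatter. Compound 3 is therefore the strongest inhibitor among the measured compounds.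

Compound 4 `COc1ccc2c(c1)CCN(CCCCCC(Sc1ccc(C)cc1)c1ccc(OC)c(OC)c1)C2` has not been measured. It differs from compound 3 in one place: hydrogen in place of methoxy on an aromatic carbon. The rest of the molecule, the chain, the thioether and the aryl group carrying two methoxy groups, stays as in compound 3.

Among the measured compounds shown here, no pair of measured compounds shows this change on its own, so there is no measured step to lean on. For the measured compounds named here, the shared core carries two methoxy groups in every measured compound, and compound 4 is the first with only one. The expectation is a modest move towards a higher number, near the edge of the scatter rather than far beyond it, giving an expected step of a 2.3-fold higher number from compound 3 to compound 4 (0.36 log units; beyond the scatter). Compound 4 is estimated at 750 nM, within a range from 250 nM to 2200 nM.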

Compound 4, half-maximal inhibitory concentration: 3090 nM
Compound 4: the middle estimate sits 4.1-fold (0.61 log units) below what was measured, and the stated range ends below it.
By their numbers in this assay, from the lowest: compound 3; then compound 2; then compounds 4 and 1 (each within the scatter of the next).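

Measured in this assay the change to hydrogen in place of methoxy on an aromatic carbon of the shared core gives a 9.4-fold higher number from compound 3 to compound 4 (0.97 log units; beyond the scatter) with nothing else in the molecule altered. Among the compounds shown here, this is the first change in one place that can be read, and it shows that this single methoxy group carries much of the inhibition seen with compound 3. No measurement at hand speaks to why its loss weakens inhibition.

Still open, from the compounds shown here alone, is whether this aromatic carbon needs methoxy itself or would keep the lower number with a hydroxyl group, an ethoxy group or a fluorine atom. Also open, going by these compounds, is how much the remaining methoxy group on the shared core contributes, and whether its removal would cost as much as this step.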